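This account rests on a few compounds, and the source may have more. Where it says the series, first, only, none or still open, it means among the compounds named here.

Series notes. The shared core is carried by compound 1 `Cc1cc(-c2ccc(Cl)cc2)c(S(C)(=O)=O)cc1C(=O)N=C(N)N`, compound 2 `Cc1cc(-c2ccccc2)c(S(C)(=O)=O)cc1C(=O)N=C(N)N`, compound 3 `Cc1cc(Sc2ccc(Cl)cc2)c(S(C)(=O)=O)cc1C(=O)N=C(N)N` and compound 4 `Cc1cc(Sc2ccccc2)c(S(C)(=O)=O)cc1C(=O)N=C(N)N`. In a functional assay for inhibition of sodium/hydrogen exchanger (Oryctolagus cuniculus) (a lower number here means a stronger inhibitor, a higher number a weaker inhibitor), compound 1 gives 45 nM, compound 2 gives 19 nM and compound 3 gives 19 nM; compound 4 is not yet measured. The cores of compound 1 and compound 3 differ by (4-chlorophenyl)sulfanyl in place of 4-chlorophenyl on an aromatic carbon, a change that gave a 2.4-fold lower number from compound 1 to compound 3 (0.37 log units; beyond the scatter). Compound 2 and compound 3 sit together at the low end of the three numbers: no change at the digits printed from compound 2 to compound 3 (within the scatter).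

The change under study is hydrogen in place of chloro on an aromatic carbon. Among the compounds here it occurs twice: once between compound 1 and compound 2, where it gave a 2.4-fold lower number from compound 1 to compound 2 (0.37 log units; beyond the scatter), and once between compound 3 and compound 4, where it reads (hydrogen in place of chloro on an aromatic carbon). The place of the change is described in the same words both times, so it counts as the same change made on a second core.

For compound 4 the expected step is a 2.1-fold lower number from compound 3 to compound 4 (0.32 log units; beyond the scatter), set beside the measured 2.4-fold lower number from compound 1 to compound 2 (0.37 log units; beyond the scatter); it rests on that single earlier example, so the expectation is held loosely. Compound 4 is therefore estimated at 9 nM, within a range from 4 nM to 22 nM.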

Compound 4, half-maximal inhibitory concentration: 14 nM
Beside the measured number, compound 4's estimate is 1.6-fold (0.19 log units) below it, within the range that was stated.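

In this assay, hydrogen in place of chloro on the second core gave a 1.4-fold lower number from compound 3 to compound 4 (0.13 log units; within the scatter), and the two examples of this change do not differ measurably: the same change on two cores in this assay, a 2.4-fold lower number (0.37 log units; beyond the scatter) from compound 1 to compound 2 and a 1.4-fold lower number (0.13 log units; within the scatter) from compound 3 to compound 4, 1.7-fold (0.24 log units) apart, within the scatter of two such steps The change therefore carries from the core of compound 1 to the core of compound 3 without a detectable difference in step size, but the step on the second core lies within the scatter, and two cores are too few to establish a rule for the series. Of the other new steps, a 1.4-fold lower number from compound 2 to compound 4 (0.13 log units; within the scatter) also stays within the scatter, while a 3.2-fold lower number from compound 1 to compound 4 (0.51 log units; beyond the scatter) is the only one beyond it.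

The compounds shown leave open whether the step would look the same with a fluoro, methoxy or amine in place of the chloro on that aromatic carbon. They also leave open how the change behaves when an ether oxygen or a methylene links the aromatic ring to the shared core, rather than a sulfur or a direct bond.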